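The source may report more compounds than this note shows. Statements on the series, on what has been measured and on what is new or still open speak of the compounds shown alone.

Compound 1, `CCN(Cc1ccccc1)C(=O)C1CCN(S(=O)(=O)c2ccc(OC)cc2)CC1`: in a functional assay on CHO cells for positive allosteric modulation of muscarinic acetylcholine receptor M5 (Homo sapiens), read by calcium flux (a higher number here means a larger maximal response, a lower number a smaller maximal response), compound 1 gives 84%.
Compound 2, `CCN(Cc1ccccc1)C(=O)C1CCN(S(=O)(=O)c2c[nH]cn2)CC1`: in this assay compound 2 gives "not determined" (no result reported).
Compound 3, `CCN(Cc1ccccc1)C(=O)C1CCN(S(=O)(=O)c2ccccn2)CC1`: in this assay compound 3 gives "not determined" (no result reported).

Compound 3 stands without a number in this assay, and compound 2 is the other entry without one, so compound 1 alone offers a value. Compound 4, `CCN(Cc1ccccc1)C(=O)C1CCN(S(=O)(=O)c2ccc3cccnc3c2)CC1`, differs from compound 3 in one place: quinolin-7-yl in place of pyridin-2-yl on a sulfonyl sulfur. Among the compounds with values here, no step between measured compounds is recorded, so the size of the change in this assay cannot be read from these data; the account expects compound 4 to sit near the maximal response of compound 1, with no direction beyond the usual scatter favoured. Compound 4 is therefore expected to reach about 80%, within a range from 50% to 110%.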

Compound 4, largest response reached (reported as percent of maximum), in percent of the reference or control that the assay uses: 66%
The estimate for compound 4 lay 14 percentage points above the measured number; measured number inside the range.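

In this assay, quinolin-7-yl in place of 4-methoxyphenyl on the sulfonyl sulfur gives a number 18 percentage points lower from compound 1 to compound 4 (beyond the scatter). Within the data shown here, this is the first number at this place for a group with a ring nitrogen, and it shows that such a group can still give a clear maximal response, though a smaller one. Compound 3 has no number, so the change from pyridin-2-yl to quinolin-7-yl cannot be read, and nothing shown explains the drop. As far as these compounds go, whether it follows from the ring nitrogen or the second ring stays open. So does how an unsubstituted phenyl or a methyl group would behave on the sulfonyl sulfur.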